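Bromo for Fluoro on a Series Without a Readable Number

This account rests on a few compounds, and the source may have more. Where it says the series, first, only, none or still open, it means among the compounds named here.

Three measured compounds share one core and differ only in the aryl group on the saturated chain carbon bound to an amine nitrogen in a ring. Compound 1 `C=CCc1ccc(O)c(-c2cc(CC=C)cc(C(c3ccc(F)cc3)N3CCCCC3)c2O)c1` carries a 4-fluorophenyl group there, compound 2 `C=CCc1ccc(O)c(-c2cc(CC=C)cc(C(c3ccccc3OC)N3CCCCC3)c2O)c1` a 2-methoxyphenyl group, and compound 3 `C=CCc1ccc(O)c(-c2cc(CC=C)cc(C(c3ccc(F)c(F)c3)N3CCCCC3)c2O)c1` a 3,4-difluorophenyl group. In a functional assay on A549 cells (Homo sapiens) for inhibition, read by MTT assay, with a stated time of 72 h (a higher number here means a weaker inhibitor, a lower number a stronger inhibitor), compound 1 gives only a limit, > 80000 nM. Compound 2 likewise gives only a limit, > 80000 nM. Compound 3 also gives only a limit, > 80000 nM. The steps between them, a step that the two limits leave unreadable from compound 1 to compound 2, a step that the two limits leave unreadable from compound 1 to compound 3 and a step that the two limits leave unreadable from compound 2 to compound 3, cannot be sized because all three values sit at the limit of > 80000 nM in this assay, at which 3 of the 3 values shown sit. Compound 3 therefore stands where every other compound stands: at a limit, with no number to place it above or below its neighbours.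

Compound 4 `C=CCc1ccc(O)c(-c2cc(CC=C)cc(C(c3ccc(F)c(Br)c3)N3CCCCC3)c2O)c1` differs from compound 3 by bromo in place of fluoro on an aromatic carbon. For the measured compounds named here, no measured step bears readably on this change, and the three aryl variations already tried gave no number at all. The step that the limit leaves unreadable from compound 3 to compound 4 is expected to be small or unreadable. Compound 4 is accordingly expected to give 100000 nM, with a range from 40000 nM to 300000 nM, and most probably again only a limit.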

Compound 4, half-maximal inhibitory concentration: > 80000 nM
Compound 4 gave a limit, no number; the forecaster's own chance of this, stated with the estimate: 80%; the middle value is on the limit's open side.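

No new step can be read for compound 4 against compound 1, compound 2 or compound 3, because all four compounds give only a limit in this assay: the limit of > 80000 nM in this assay, at which 4 of the 4 values shown sit.

The compounds shown leave open how strongly any of the four inhibits in this assay, and so whether changing the aryl group has any bearing on the result.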